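Notes on the aryl change at compound 4

The source may hold more compounds than are shown below. What is called first, only, known or untested is meant among the compounds shown, and "the series" means these compounds.

Values in a functional assay on SW-620 cells (Homo sapiens) for cytotoxicity; on this read-out lower numbers stand for stronger inhibition of growth and higher numbers for weaker inhibition of growth:
- compound 1 `COc1ccc(C2=C(c3cc(OC)c(OC)c(OC)c3)CC3CCCN3C2=O)cc1O`: > 100000 nM, a limit
- compound 2 `COc1ccc(C2=C(c3ccc(SC)cc3)CC3CCCN3C2=O)cc1OC(=O)CNC(=O)OC(C)(C)C`: 20000 nM
- compound 3 `COc1ccc(C2=C(c3ccc(SC)cc3)CC3CCCN3C2=O)cc1Br`: 5000 nM

Of the two values that are true numbers, compound 3 has the lower. Compound 4 `CSc1ccc(C2=C(c3ccc(C)c(C)c3)C(=O)N3CCCC3C2)cc1` carries 3,4-dimethylphenyl in place of 3-bromo-4-methoxyphenyl on a double-bonded ring carbon. Going by the values given here, one measured step touches this aryl group: a 4.0-fold lower number from compound 2 to compound 3 (0.60 log units; beyond the scatter), modest and beyond the scatter. Among the compounds with values here, no measured step replaces the methoxy group or the bromine with methyl, so the direction is tentative. A modest move toward weaker growth inhibition in this assay is expected, with an estimated 2.0-fold higher number from compound 3 to compound 4 (0.30 log units; within the scatter). For compound 4 the estimate is 10000 nM, with an expected range of 2500 nM to 40000 nM.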

Compound 4, concentration for 50% growth inhibition: 700 nM
The estimate for compound 4 lay 14-fold (1.15 log units) above the measured number; the measured number lies below the stated range.
By their numbers in this assay, from the lowest: compound 4; then compound 3; then compound 2. At a limit, above all of these: compound 1.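

At the double-bonded ring carbon, 3,4-dimethylphenyl in place of 3-bromo-4-methoxyphenyl gives, in this assay, a 7.1-fold lower number from compound 3 to compound 4 (0.85 log units; beyond the scatter). Stronger growth inhibition at this position therefore needs neither the bromine nor the methoxy oxygen of compound 3. No measured property bears on why this change lowers the number.

On these data alone, the two substituents change together, so the share of the step belonging to each stays open. Also open, as far as these compounds go, is how an amine, a carboxylic acid or a longer chain on this aryl ring would read out.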